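The compounds below may be only part of what the source reports. "The series", "measured", "known", "first", "only" and "open" are said of these compounds alone.

Three compounds share one core and differ only in the group attached to a single aromatic carbon of that core. Compound 1 `COc1cccc(-c2cc(-c3cc(C(C)C)c(O)cc3C)[nH]c(=O)c2C#N)c1` carries a 3-methoxyphenyl group there, and in a functional assay for inhibition, tested at 40 ug/mL (a lower number here means a weaker effect, a higher number a stronger effect of the compound at the concentration tested), compound 1 gives 30%. Compound 2 `COc1cc(-c2cc(-c3cc(C(C)C)c(O)cc3C)[nH]c(=O)c2C#N)ccc1O` adds a hydroxy group to that same ring, and in this assay compound 2 gives 32%. Compound 3 `Cc1cc(O)c(C(C)C)cc1-c1cc(-c2ccco2)c(C#N)c(=O)[nH]1` carries a furan-2-yl group instead, and in this assay compound 3 gives 42.5%. Compound 1 thus stands lowest of the three, close to compound 2 and furthest from compound 3.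

The new compound 4 `COc1ccc(-c2cc(-c3cc(C(C)C)c(O)cc3C)[nH]c(=O)c2C#N)cc1OC` differs from compound 1 in one place: methoxy in place of hydrogen on an aromatic carbon. The step that bears most directly on this change is the addition of a small group on the same ring, where the read-out moved a number 2 percentage points higher from compound 1 to compound 2 (within the scatter). The larger moves, a number 12.5 percentage points higher from compound 1 to compound 3 (beyond the scatter) and a number 10.5 percentage points higher from compound 2 to compound 3 (beyond the scatter), come from exchanging the whole ring and say little about adding a methoxy group. For compound 4 the expected step is therefore a number 2 percentage points higher from compound 1 to compound 4 (within the scatter), staying within the scatter. Compound 4 is thus estimated at 32%, with a range from 20% to 44%.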

Compound 4, a percentage reported as inhibition, at one concentration (the size of the read-out at that concentration, not a potency): 44%
Estimate against measurement, compound 4: 12 percentage points below; low and high end bracket the measured number.
By their numbers in this assay, from the lowest: compounds 1 and 2 (each within the scatter of the next); then compounds 3 and 4 (each within the scatter of the next).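

In this assay, the carbon ortho to a methoxy group and para to a large group turns out to respond to what is placed on it: adding methoxy there moves the read-out a number 14 percentage points higher from compound 1 to compound 4 (beyond the scatter) in this comparison, while adding hydroxy at that same carbon gave only a number 2 percentage points higher from compound 1 to compound 2 (within the scatter) in the earlier one. The difference between those two groups can also be read directly, since putting a methyl on the oxygen of the hydroxy group gives a number 12 percentage points higher from compound 2 to compound 4 (beyond the scatter) and nothing else changes between the two structures. The 3,4-dimethoxyphenyl group also brings a six-membered ring to the level of the furan-2-yl group, with a number 1.5 percentage points higher from compound 3 to compound 4 (within the scatter) as the step, so exchanging the phenyl ring for furan-2-yl is not the only route to that level.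

From the compounds shown here alone, whether an ethoxy group, a longer chain or an amine on this same carbon would keep, raise or lower the read-out remains open. Nothing measured here gives a reason for the gap between hydroxy and methoxy at this carbon.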